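Boronic acid amide series: cytotoxicity in human fibroblasts

A few compounds are considered here, and "the series" means these few. Any claim that something is new, unique, unknown or untested is made for them only; others in the source may bear on it.

Measured so far:
compound 1, `O=C(CCc1cccc2c1B(O)OC2)NCc1ccccc1` — > 100000 nM
compound 2, `O=C(CCc1cccc2c1B(O)OC2)Nc1ccc(I)cc1` — 49000 nM
compound 3, `O=C(CCc1cccc2c1B(O)OC2)Nc1cccc(Br)c1` — 20000 nM

Compound 1 sits at a limit of an ADME assay on WI-38 cells (Homo sapiens) for cytotoxicity, read by MTT assay, with a stated time of 72 h (a lower number here means a stronger inhibitor, a higher number a weaker inhibitor), (the limit of > 100000 nM in this assay, at which 1 of the 3 values shown sits), and gives no number. Of the two numbers that exist, compound 2 holds the higher one; its nearest neighbour is compound 3, separated by a 2.5-fold lower number from compound 2 to compound 3 (0.39 log units; beyond the scatter). Against the limit of compound 1 the aryl amides show an at least 2.0-fold lower number from compound 1 to compound 2 (0.30 log units; that floor lies within the scatter) and an at least 5.0-fold lower number from compound 1 to compound 3 (0.69 log units; beyond the scatter).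

Compound 4, `O=C(CCc1cccc2c1B(O)OC2)Nc1ccc(-c2ccccc2)cc1`, differs from compound 2 by phenyl in place of iodo on an aromatic carbon. For the measured compounds named here, no measured step exchanges a halogen for an aromatic ring on the amide-bound phenyl, so the only guidance is that the three aryl amides stay within a narrow band once the benzyl of compound 1 is left behind, and that band spans a 2.5-fold lower number from compound 2 to compound 3 (0.39 log units; beyond the scatter) at most. For compound 4 a step of about a 1.6-fold lower number from compound 2 to compound 4 (0.21 log units; within the scatter) is therefore expected, a modestly lower number that may not exceed the scatter. Compound 4 is estimated at 30000 nM, with a range from 10000 nM to 100000 nM.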

Compound 4, half-maximal inhibitory concentration: 32000 nM
Estimate against measurement, compound 4: 1.1-fold (0.03 log units) below, and the stated range covers the measured number.
By their numbers in this assay, from the lowest: compounds 3, 4 and 2 (each within the scatter of the next, the first and the last beyond it). At a limit, above all of these: compound 1.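

On an aromatic carbon of the amide-bound phenyl, para to a large group, phenyl in place of iodo gives a 1.5-fold lower number from compound 2 to compound 4 (0.19 log units; within the scatter) in this assay. This step brings in 6 heavy atoms and a six-membered aromatic ring where iodo had 1 heavy atom, yet compound 2 and compound 4 remain within the scatter of each other, so this position shows no measurable sensitivity to this exchange. Nothing shown here gives a reason for this step.

On these data alone, whether the same holds for an amine, a carboxylic acid or a longer chain at this place remains open. Also open, as far as these compounds go, is whether a phenyl group here would read the same way on an amide whose nitrogen carries benzyl, as in compound 1.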